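Triazole-linked terpenoid esters: cytotoxicity at the assay limit

The compounds below may be only part of what the source reports. "The series", "measured", "known", "first", "only" and "open" are said of these compounds alone.

Compound 1 `C/C(=C\CC/C(C)=C/CC[C@@H]1[C@@]2(C)CCC(=O)C(C)(C)[C@H]2CC[C@@]1(C)O)CC/C=C(\C)C(=O)OCc1cn(-c2ccccc2[N+](=O)[O-])nn1` — > 150000 nM in an ADME assay on L132 cells (Homo sapiens) for cytotoxicity, read by MTT assay, with a stated time of 48 h; a lower number here means a stronger inhibitor, a higher number a weaker inhibitor
Compound 2 `C/C(=C\CC/C(C)=C/CC[C@@H]1[C@@]2(C)CCC(=O)C(C)(C)[C@H]2CC[C@@]1(C)O)CC/C=C(\C)C(=O)OCc1cn(-c2ccccc2Br)nn1` — > 150000 nM in this assay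
Compound 3 `C/C(=C\CC/C(C)=C/CC[C@@H]1[C@@]2(C)CCC(=O)C(C)(C)[C@H]2CC[C@@]1(C)O)CC/C=C(\C)C(=O)OCc1cn(-c2ccc(C)cc2)nn1` — > 150000 nM in this assay

Compound 2 sits at the limit of this assay, and its value is a limit rather than a number. The same is true of compound 1 and of compound 3, so all three measured compounds stand together at the limit of > 150000 nM in this assay, at which 3 of the 3 values shown sit, and no one of them can be placed above or below another.

Compound 4 `C/C(=C\CC/C(C)=C/CC[C@@H]1[C@@]2(C)CCC(=O)C(C)(C)[C@H]2CC[C@@]1(C)O)CC/C=C(\C)C(=O)OCc1cn(-c2ccc(C(C)(C)C)cc2)nn1` has not yet been measured. It differs from compound 2 by 4-(tert-butyl)phenyl in place of 2-bromophenyl on an aromatic nitrogen. The measured steps that bear on this change are a step that the two limits leave unreadable from compound 2 to compound 3, a step that the two limits leave unreadable from compound 1 to compound 3 and a step that the two limits leave unreadable from compound 1 to compound 2; each joins two limits, and none gives a readable size. With every aryl group seen so far landing at the limit, compound 4 is expected to stay at the limit as well, with no step beyond the scatter: a step that the limit leaves unreadable from compound 2 to compound 4. For compound 4 the estimate in this assay is 200000 nM, within a range from 100000 nM to 400000 nM, most likely reported again only as a limit.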

Compound 4, half-maximal inhibitory concentration: 65800 nM
Beside the measured number, compound 4's estimate is 3.0-fold (0.48 log units) above it; the whole stated range lies above it.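

Within the data shown here, the tert-butyl group gives the first readable number in this assay, so the group on this phenyl ring can shift the read-out, which the earlier compounds could not show. The closest comparison changes only tert-butyl for methyl on an aromatic carbon and gives an at least 2.2-fold lower number from compound 3 to compound 4 (0.35 log units; beyond the scatter), while the wider aryl exchanges give an at least 2.2-fold lower number from compound 2 to compound 4 (0.35 log units; beyond the scatter) and an at least 2.2-fold lower number from compound 1 to compound 4 (0.35 log units; beyond the scatter). Each of these sizes is only a minimum and the steps among compound 1, compound 2 and compound 3 still cannot be read, because those compounds carry only a limit: the limit of > 150000 nM in this assay, at which 3 of the 4 values shown sit.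

The compounds shown leave open whether an isopropyl group, with a chain of intermediate branching, would also give a readable number. They also leave open how an amine or a carboxylic acid in place of tert-butyl on the same ring would behave.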